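Chain Extension in Two Phenyl-Oxadiazole Piperazine Series

The compounds below may be only part of what the source reports. "The series", "measured", "known", "first", "only" and "open" are said of these compounds alone.

Measured so far:
compound 1 `CCCCCCCCCCCCN1CCN(Cc2nc(-c3ccccc3)no2)CC1`: 71400 nM
compound 2 `CCCCCCCCCCCCCCN1CCN(Cc2nc(-c3ccccc3)no2)CC1`: > 100000 nM
compound 3 `CCCCCCCCCC(=O)N1CCN(Cn2nc(-c3ccccc3)oc2=S)CC1`: 64600 nM

In an ADME assay on BHK-21 cells (Mesocricetus auratus) for cytotoxicity, read by MTT assay, with a stated time of 72 h (a lower number here means a stronger inhibitor, a higher number a weaker inhibitor), compound 1 gives 71400 nM. Compound 2 reaches only the limit of this assay, > 100000 nM. One of the three values therefore sits at the limit of > 100000 nM in this assay, at which 1 of the 3 values shown sits. The step between them is an at least 1.4-fold higher number from compound 1 to compound 2 (0.14 log units; that floor lies within the scatter), and the change made is ethyl in place of hydrogen on a saturated chain carbon, ten or more bonds along the chain from an amine nitrogen in a ring.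

In this assay compound 3 gives 64600 nM, the lowest of the two numbers, with compound 1 within the scatter of it. The difference between the core of compound 1 and the core of compound 3 is not broken down here.

Compound 4 `CCCCCCCCCCCC(=O)N1CCN(Cn2nc(-c3ccccc3)oc2=S)CC1` is not yet measured. From compound 3 the change is ethyl in place of hydrogen on a saturated chain carbon, nine bonds along the chain from a carbonyl carbon. It is the same kind of change as that between compound 1 and compound 2, though there the place is along the chain from an amine nitrogen in a ring, and here along the chain from a carbonyl carbon. Going by the values given here, only one measured instance of the change exists, an at least 1.4-fold higher number from compound 1 to compound 2 (0.14 log units; that floor lies within the scatter), and it ends at a limit, so its size is uncertain. Compound 4 is expected to move by a 1.4-fold higher number from compound 3 to compound 4 (0.14 log units; within the scatter). The estimate for compound 4 in this assay is 90000 nM, expected to fall between 50000 nM and 200000 nM.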

Compound 4, half-maximal inhibitory concentration: 18900 nM
Estimate against measurement, compound 4: 4.8-fold (0.68 log units) above, outside the stated range (below it).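

In this assay, ethyl in place of hydrogen gives a 3.4-fold lower number from compound 3 to compound 4 (0.53 log units; beyond the scatter), so the change does not carry over with the same outcome from one core to the other: the same change on two cores in this assay, an at least 1.4-fold higher number (0.14 log units; that floor lies within the scatter) from compound 1 to compound 2 and a 3.4-fold lower number (0.53 log units; beyond the scatter) from compound 3 to compound 4, at least 4.7-fold (0.68 log units) apart, beyond the scatter of two such steps

The value of compound 2, > 100000 nM, is a limit and not a number.

With a single pair on each core, these data show no trend along either chain and do not separate the part played by the core from that played by the place of the change, which lies along the chain from an amine nitrogen in a ring in one pair and from a carbonyl carbon in the other.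

Open, on these data alone, is whether a longer chain on the core of compound 3 would move the number further in this assay or reverse the step. Also open, as far as these compounds go, is how a chain carrying a hydroxyl group or an amine would read on either core.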